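The source may report more compounds than this note shows. Statements on the series, on what has been measured and on what is new or still open speak of the compounds shown alone.

In a physicochemical assay for solubility (on this read-out higher numbers stand for higher solubility and lower numbers for lower solubility), compound 3 (`CNCc1cccc(Cc2c([C@H](C)Nc3ncnc(N)c3C#N)cc3scc(C)n3c2=O)c1`) gives > 1000000 nM, which is a limit and not a number. Compound 1 (`Cc1csc2cc([C@H](C)Nc3ncnc(N)c3C#N)c(Cc3cccc(CN)c3)c(=O)n12`) gives > 1000000 nM, also a limit. Both sit at the limit of > 1000000 nM in this assay, at which 2 of the 3 values shown sit. Compound 2 (`Cc1csc2cc([C@H](C)Nc3ncnc(N)c3C#N)c(-c3ccccc3)c(=O)n12`) gives a true number, 77000 nM. Compound 4 (`Cc1csc2cc([C@H](C)Nc3ncnc(N)c3C#N)c(Cc3cccc(CN(C)C)c3)c(=O)n12`) follows from compound 3 through methyl in place of hydrogen on an amine nitrogen, methylamino to dimethylamino. For the measured compounds named here, the nearest precedent is the same kind of change, a step that the two limits leave unreadable from compound 1 to compound 3. The readable steps, an at least 12-fold lower number from compound 1 to compound 2 (1.11 log units; beyond the scatter) and an at least 12-fold higher number from compound 2 to compound 3 (1.11 log units; beyond the scatter), both exchange the whole benzyl substituent for phenyl or back, so they are large but a poor guide here. In this assay no step beyond the scatter is expected, and the expected step is a number no higher from compound 3 to compound 4 (the limit leaves the size open). The estimate for compound 4 is 1000000 nM, with an expected range of 400000 nM to 2500000 nM.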

Compound 4, solubility: 956000 nM
The estimate for compound 4 lay 1.0-fold (0.02 log units) above the measured number, within the range that was stated.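

At this position in this assay, a methyl on the amine nitrogen gives a true number rather than a limit, with an at least 1.0-fold lower number from compound 3 to compound 4 (0.01 log units; that floor lies within the scatter) and an at least 1.0-fold lower number from compound 1 to compound 4 (0.01 log units; that floor lies within the scatter) as floors only. For the compounds shown here, the benzyl substituent's advantage over phenyl persists with dimethylamino, with a 12-fold higher number from compound 2 to compound 4 (1.09 log units; beyond the scatter) as the first such step that rests on two true numbers.

On these data alone, compound 1 and compound 3 carry limits, so how far either lies from compound 4 stays open. Also open, as far as these compounds go, is whether a carboxylic acid or a longer chain at the end of the benzyl substituent would hold the number at this level.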